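Fluoro for Chloro on the Weakest of Three Compounds

This account rests on a few compounds, and the source may have more. Where it says the series, first, only, none or still open, it means among the compounds named here.

Among the compounds with values here, in a functional assay on DU-145 cells (Homo sapiens) for cytotoxicity, read by MTT assay (on this read-out higher numbers stand for weaker inhibition and lower numbers for stronger inhibition), compound 1 `COc1ccc(CSc2nnc([C@@H](C)c3ccc4cc(OC)ccc4c3)n2-c2ccc(Cl)cc2)cc1` gives 72600 nM, the highest number of the three measured so far. Compound 2 `COc1ccc2cc([C@H](C)c3nnc(SCc4ccc(F)cc4)n3-c3ccc(Cl)cc3)ccc2c1` gives 33600 nM. Compound 3 `COc1ccc2cc([C@H](C)c3nnc(SCc4ccc(C)cc4)n3-c3ccc(Cl)cc3)ccc2c1` gives 18800 nM. Modest steps beyond the scatter separate these two from the first: a 2.2-fold lower number from compound 1 to compound 2 (0.33 log units; beyond the scatter) and a 3.9-fold lower number from compound 1 to compound 3 (0.59 log units; beyond the scatter). Between the two themselves, a 1.8-fold lower number from compound 2 to compound 3 (0.25 log units; within the scatter) stays within the scatter.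

Compound 4 `COc1ccc(CSc2nnc([C@@H](C)c3ccc4cc(OC)ccc4c3)n2-c2ccc(F)cc2)cc1` keeps the methoxy group that those steps replace and differs from compound 1 elsewhere: fluoro in place of chloro on an aromatic carbon, which turns the 4-chlorophenyl into 4-fluorophenyl. Within the data shown here, no measured compound varies this place, so the three steps bear on it only indirectly, and the data give no direction for the change. The expectation therefore starts from compound 1 at 72600 nM, and no step beyond the scatter is expected, the estimated step being a 1.0-fold lower number from compound 1 to compound 4 (0.02 log units; within the scatter). Compound 4 is estimated at 70000 nM, with an expected range of 30000 nM to 150000 nM.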

Compound 4, half-maximal inhibitory concentration: <= 400000 nM
Compound 4 was reported as a limit (the forecaster's own chance of this, stated with the estimate: 15%); the middle value lies beyond the limit too.
By their numbers in this assay, from the lowest: compounds 3 and 2 (each within the scatter of the next); then compound 1.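

In this assay compound 4 is reported only as a limit and not as a number: the limit of <= 400000 nM in this assay, at which 1 of the 4 values shown sits.

Within the data shown here, no step from compound 1 to compound 4 can be read. The compounds shown leave open whether 4-fluorophenyl in place of 4-chlorophenyl changes the number at all, and in which direction.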